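Changing the aryl group on a long-chain urea

The compounds below may be only part of what the source reports. "The series", "measured", "known", "first", "only" and "open" are said of these compounds alone.

Compound 2, `CCCCCCCC/C=C\CCCCCCCCNC(=O)Nc1ccccc1`, is tested in an assay on microsomes from intestinal mucosa for inhibition of acyl-CoA:cholesterol acyltransferase (Oryctolagus cuniculus); a lower number here means a stronger inhibitor, a higher number a weaker inhibitor. In this assay compound 2 reaches only a limit, > 5000 nM, and no number is known for it (the limit of > 5000 nM in this assay, at which 1 of the 2 values shown sits). A related carbamate, compound 1 `CCCCCCCCCCCCCCCCCCNC(=O)Oc1c(C)cccc1C`, gives 3100 nM in this assay; the two compounds differ in more than one place, so these two values show only what each compound gives on its own. Compound 3, `CCCCCCCC/C=C\CCCCCCCCNC(=O)Nc1c(CC)cccc1C(C)C`, carries 2-ethyl-6-isopropylphenyl in place of phenyl on an amide-type nitrogen. The step from compound 2 to compound 3 is expected to be an at least 16-fold lower number from compound 2 to compound 3 (1.22 log units; beyond the scatter), toward stronger inhibition and beyond the usual scatter. Compound 3 is expected to give about 300 nM, within 50 nM to 3000 nM.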

Compound 3, half-maximal inhibitory concentration: 37 nM
Estimate against measurement, compound 3: 8.1-fold (0.91 log units) above; measured number outside the range, below it.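

Placing 2-ethyl-6-isopropylphenyl in place of phenyl on an amide-type nitrogen gives an at least 130-fold lower number from compound 2 to compound 3 (2.13 log units; beyond the scatter) in this assay. Among the compounds shown here, this is the first single-place comparison here, and it shows that the aryl group at this place has a large influence on inhibition. The true size of the step is unknown because compound 2 has only a limit of the assay, not a number: the limit of > 5000 nM in this assay, at which 1 of the 3 values shown sits.

Still open, from the compounds shown here alone, is whether an ethyl group alone or an isopropyl group alone would give a similar step. Also open, going by these compounds, is how a methoxy group or an amine on the phenyl ring would compare.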